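This account rests on a few compounds, and the source may have more. Where it says the series, first, only, none or still open, it means among the compounds named here.

Compound 1, `C#CCOc1noc2c1CNCC2`, gives 7.6.
Compound 2, `CCOc1noc2c1CN(C)CC2`, gives 6.6.

In a physicochemical assay for acid dissociation, compound 1 holds the higher of the two numbers, with compound 2 lower by a gap beyond the usual scatter. The next compound is compound 3, `CC(C)COc1noc2c1CNCC2`, which differs from compound 1 by isopropyl in place of ethynyl on a saturated chain carbon bound to an oxygen on an aromatic ring. Among the compounds with values here, no measured pair shows this change, so its effect is unknown; the change sits away from the ring nitrogen, and only a small step in this assay, if any, is expected. Compound 3 is estimated at 7.8, in the range 7.3 to 8.3, a step of a number 0.20 log units higher from compound 1 to compound 3 (within the scatter).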

Compound 3, acid dissociation constant: 7.7
Compound 3: the middle estimate sits 0.10 log units above what was measured; the measured number falls inside the stated range.
By their numbers in this assay, from the lowest: compound 2; then compounds 1 and 3 (each within the scatter of the next).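

In this assay, isopropyl in place of ethynyl on a saturated chain carbon bound to an oxygen on an aromatic ring gives a number 0.10 log units higher from compound 1 to compound 3 (within the scatter). At this place, then, the triple bond can leave and a branched group can enter without a readable shift in the number. No measurement shown explains this result. As far as these compounds go, whether an amine or a carboxylic acid on this chain would also leave the number in place remains open. Compound 2 differs from compound 1 and compound 3 in more than one place, so its step cannot be read.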